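This account rests on a few compounds, and the source may have more. Where it says the series, first, only, none or still open, it means among the compounds named here.

Of the compounds shown here, two have been measured. Compound 1 `O=S(=O)(NCCNCc1cccc2ccccc12)c1cc(C(F)(F)F)cc(C(F)(F)F)c1` carries a naphthyl group on the amine side; in a functional assay on BXPC-3 cells (Homo sapiens) for inhibition, read by MTT assay, with a stated time of 72 h (on this read-out lower numbers stand for stronger inhibition of growth and higher numbers for weaker inhibition of growth), compound 1 gives 23000 nM. Compound 2 `O=S(=O)(NCCNCc1ccc(-c2ccccc2)cc1)c1cc(C(F)(F)F)cc(C(F)(F)F)c1` replaces that group with a biphenyl arrangement, and in this assay compound 2 gives 1600 nM, the lower of the two numbers; the gap to compound 1 is well beyond the scatter of repeated measurement. Going by the values given here, no single-point step between measured compounds is available, so nothing about the effect of a single group change has yet been seen directly.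

Compound 3 `CC(C)(C)c1ccc(CNCCNS(=O)(=O)c2cc(C(F)(F)F)cc(C(F)(F)F)c2)cc1` is the next point. Relative to compound 2 the change is tert-butyl in place of phenyl on an aromatic carbon, so a tert-butyl group stands where the outer phenyl of compound 2 stood. Among the compounds with values here, no measured step matches this change, and the only comparison to hand is between two quite different aromatic groups. The expectation is a step from compound 2 to compound 3 of no more than modest size, a 1.6-fold higher number from compound 2 to compound 3 (0.19 log units; within the scatter), most likely towards a somewhat higher number but possibly within the scatter. For compound 3 the estimated value in this assay is 2500 nM, with a range from 800 nM to 8000 nM.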

Compound 3, concentration for 50% growth inhibition: 8800 nM
The estimate for compound 3 lay 3.5-fold (0.55 log units) below the measured number, outside the stated range (above it).
By their numbers in this assay, from the lowest: compound 2; then compound 3; then compound 1.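

In this assay, the aromatic carbon para to a large group now has its first direct single-place reading: tert-butyl in place of phenyl (a 5.5-fold higher number from compound 2 to compound 3 (0.74 log units; beyond the scatter)) is a step beyond the scatter, although neither group counts any hydrogen-bond donors, hydrogen-bond acceptors or net charge, and only phenyl brings a six-membered aromatic ring of carbon only. The other new comparison, 4-(tert-butyl)phenyl in place of naphthalen-1-yl on the saturated chain carbon bound to the amine nitrogen (a 2.6-fold lower number from compound 1 to compound 3 (0.42 log units; beyond the scatter)), is also beyond the scatter, so the three numbers are separated and run from compound 2 through compound 3 to compound 1. No measurement on hand gives a reason for either step.

The compounds shown do not separate the presence of an aromatic ring at this carbon from the size of the group, which a cyclohexyl or a pyridyl group in the same place could address. Going by these compounds, the trifluoromethyl groups and the ethylene chain are also common to all three compounds, so the effect of a nitrile in place of trifluoromethyl or of a longer chain remains open.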